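Ester variation on a phenylpyrazole scaffold against HL-60 cells

The source may hold more compounds than are shown below. What is called first, only, known or untested is meant among the compounds shown, and "the series" means these compounds.

Measured compounds:
Compound 1, `Cc1ccc(C(C)C)c(OC(=O)c2cn(-c3ccccc3)nc2-c2cccnc2)c1`: 22700 nM
Compound 2, `CCc1ccc(OC(=O)c2cn(-c3ccccc3)nc2-c2ccncc2)cc1`: "nd(insoluble)" (no result reported)

The study concerns two esters of a shared pyrazole core and another compound that has not yet been tested. In a functional assay on HL-60 cells (Homo sapiens) for cytotoxicity, read by MTT assay, with a stated time of 48 h (a higher number here means a weaker inhibitor, a lower number a stronger inhibitor), compound 1 gives 22700 nM. Among the compounds with values here, for compound 2 this assay gives "nd(insoluble)" (no result reported), so no number stands against it and no step from it can be put in figures. Compound 3, `Cc1ccc(C(C)C)c(OC(=O)c2cn(-c3ccccc3)nc2-c2ccncc2)c1`, is built from compound 2 by the change (2-isopropyl-5-methylphenyl in place of 4-ethylphenyl on an oxygen next to a carbonyl group). Within the data shown here, no measured step is available for this change, so its size and direction cannot be read from the data. Compound 3 carries the same 2-isopropyl-5-methylphenyl group as compound 1, and in this assay compound 1 gives 22700 nM, which is the only anchor on hand. On that basis compound 3 is expected to land near compound 1, at an estimated 22000 nM in this assay, with a plausible range from 6000 nM to 80000 nM, and a real chance that only a limit is reported.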

Compound 3, half-maximal inhibitory concentration: 17800 nM
Beside the measured number, compound 3's estimate is 1.2-fold (0.09 log units) above it; the range from low to high includes it.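

In this assay, putting pyridin-4-yl in place of pyridin-3-yl on an aromatic carbon, with the 2-isopropyl-5-methylphenyl group held fixed, gives a 1.3-fold lower number from compound 1 to compound 3 (0.11 log units; within the scatter), so the two pyridine groups cannot be told apart in this read-out on the shared core. The step from compound 2 to compound 3 cannot be read, as compound 2 has no number, and the swap of 4-ethylphenyl for 2-isopropyl-5-methylphenyl therefore has no measured size; what is new is that a compound carrying pyridin-4-yl now has a number at all, with compound 3 at 17800 nM. No supporting measurement bears on this result, so the data offer no account of it.

The compounds shown give no readable comparison between two different groups on the ester oxygen, so it remains open whether that group affects the number in this assay at all. Going by these compounds, it also remains open whether a pyridin-2-yl group on that aromatic carbon, or an amide in place of the ester, would move the number beyond the usual scatter.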